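Chloro Step Repeated on Two Related Sulfonamide Cores

The source may hold more compounds than are shown below. What is called first, only, known or untested is meant among the compounds shown, and "the series" means these compounds.

Compound 1 `C[C@@H]1CN(c2cccc(NS(=O)(=O)c3ccc(-c4ccccn4)s3)c2)C[C@H](C)N1` and compound 2 `C[C@@H]1CN(c2ccc(Cl)c(NS(=O)(=O)c3ccc(-c4ccccn4)s3)c2)C[C@H](C)N1` share one core and differ in a single place: chloro in place of hydrogen on an aromatic carbon, with the chloro group sitting on an aromatic carbon of a six-membered aromatic ring of carbon only, ortho to a large group and para to a 3,5-dimethylpiperazin-1-yl group. In a functional assay for agonist activity at growth hormone secretagogue receptor type 1 (Homo sapiens), read by FLIPR (a lower number here means that less compound is needed, a higher number that more compound is needed for the effect), compound 1 gives 39.8 nM, and compound 2 gives 39.8 nM, so that no change at the digits printed from compound 1 to compound 2 (within the scatter). Compound 3 `COc1ccc(N2C[C@@H](C)N[C@@H](C)C2)cc1NS(=O)(=O)c1ccc(-c2cccs2)cc1` rests on a different core; the difference between the two cores is not broken down here. In this assay compound 3 gives 3.98 nM, the lowest of the three numbers, with its steps to compound 1 and compound 2 both beyond the scatter. Compound 4 `COc1ccc(N2C[C@@H](C)N[C@@H](C)C2)cc1NS(=O)(=O)c1ccc(-c2cccs2)cc1Cl` arises from compound 3 by chloro in place of hydrogen on an aromatic carbon, the same kind of change, here placed ortho to a large group and meta to a thiophen-2-yl group. The step of a 1.1-fold higher number from compound 3 to compound 4 (0.05 log units; within the scatter) is expected to be small because the step of no change at the digits printed from compound 1 to compound 2 (within the scatter) stayed within the scatter. Compound 4 is therefore estimated at 4.5 nM, between 2 nM and 10 nM.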

Compound 4, half-maximal effective concentration: 0.794 nM
Compound 4: the middle estimate sits 5.7-fold (0.75 log units) above what was measured; measured number below the stated range.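

Read in this assay, the chloro change on the core of compound 3 gives a 5.0-fold lower number from compound 3 to compound 4 (0.70 log units; beyond the scatter), so the absence of any visible change on the core of compound 1 did not carry over to this second core. Set side by side, the two outcomes of the same change differ: the same change on two cores in this assay, no change at the digits printed (within the scatter) from compound 1 to compound 2 and a 5.0-fold lower number (0.70 log units; beyond the scatter) from compound 3 to compound 4, 5.0-fold (0.70 log units) apart, beyond the scatter of two such steps. This shows that, across these two pairs, the result of adding the chloro group depends on its setting, but it does not show whether the gap comes from the differences between the two cores or from where the chloro group sits on each, and two pairs cannot predict the result on a third core.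

The compounds shown leave open whether fluoro, methyl or a nitrile on the same aromatic carbon of compound 4 would give a similar number to chloro. They also leave open how the chloro step would fare if a carboxylic acid or an amine took the place of the thiophen-2-yl group.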